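Working notes: aryl ketone of compound 2 replaced by fluorosulfonyloxy

A few compounds are considered here, and "the series" means these few. Any claim that something is new, unique, unknown or untested is made for them only; others in the source may bear on it.

Measured so far:
compound 1 `CC1(C)C=C(n2ccccc2=O)c2cc(C(=O)c3ccccc3[N+](=O)[O-])ccc2O1` — 6.17
compound 2 `Cc1ccccc1C(=O)c1ccc2c(c1)C(n1ccccc1=O)=CC(C)(C)O2` — 6.83

In a functional assay (aorta) with Rattus norvegicus as the target (on this read-out lower numbers stand for lower potency and higher numbers for higher potency (the scale is a negative logarithm)), compound 2 stands highest of the two numbers shown. Among the measured compounds shown here, the nearest is compound 1, and the one step between them, a number 0.66 log units higher from compound 1 to compound 2 (beyond the scatter), lies beyond the scatter.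

The next compound is compound 3 `CC1(C)C=C(n2ccccc2=O)c2cc(OS(=O)(=O)F)ccc2O1`. It differs from compound 2 by (fluorosulfonyl)oxy in place of (2-methylphenyl)carbonyl on an aromatic carbon. For the measured compounds named here, the only measured step in this assay concerns a change of a single substituent on the aromatic ring of the (2-methylphenyl)carbonyl group, while here that whole group leaves and a group of a different kind enters at the same aromatic carbon of the shared core. No measured step therefore bears on this change, and neither its direction nor its size can be read from the two numbers shown. The step of a number 0.53 log units lower from compound 2 to compound 3 (beyond the scatter) is accordingly estimated as a wide guess centred close to the number for compound 2. Compound 3 is expected to give 6.3 in this assay, within 5.3 to 7.3.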

Compound 3, logarithm of the reciprocal of the active concentration, log(1/C): 7.95
Compound 3: the middle estimate sits 1.65 log units below what was measured, outside the stated range (above it).
By their numbers in this assay, from the lowest: compound 1; then compound 2; then compound 3.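

In this assay, replacing (2-methylphenyl)carbonyl with (fluorosulfonyl)oxy on this aromatic carbon gives a number 1.12 log units higher from compound 2 to compound 3 (beyond the scatter), a larger step than the substituent change within the aryl ketone, a number 0.66 log units higher from compound 1 to compound 2 (beyond the scatter). The six-membered aromatic ring of the (2-methylphenyl)carbonyl group is therefore not needed for a high number at this position, since a group with no ring reaches a higher number on the shared core than either aryl ketone does. No measurement at hand accounts for this step, and the reason for it remains unknown.

The compounds shown cannot tell whether the step depends on the fluorosulfonyl group as a whole or would also appear with methanesulfonyloxy, a hydroxyl or a nitrile on the same aromatic carbon. Among the compounds shown here, with (fluorosulfonyl)oxy as the only group without a ring at this position, they also leave open whether any trend runs across ring-free groups, and a comparison with a plain acetyl or a methoxy group would begin to settle that.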